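The source may report more compounds than this note shows. Statements on the series, on what has been measured and on what is new or still open speak of the compounds shown alone.

In a functional assay on V79 cells (Cricetulus griseus) for cytotoxicity, read by colony formation (a lower number here means a stronger inhibitor, a higher number a weaker inhibitor), compound 1 `CCNCC1CCN(c2c(F)cc3c(=O)c(C(=O)O)cn(C4CC4)c3c2F)C1` gives 11 ug/mL; 11 ug/mL; 11 ug/mL; 11 ug/mL (4 entries) and compound 2 `CCNCC1CCN(c2c(F)c(F)c3c(=O)c(C(=O)O)cn(C4CC4)c3c2F)C1` gives 46 ug/mL, the higher number and so the weaker inhibitor of the two. Among the compounds with values here, compound 2 has only this one number, and one further entry for it holds no single number. Compound 3 `CCNCC1CCN(c2c(F)c(NC)c3c(=O)c(C(=O)O)cn(C4CC4)c3c2F)C1` is not yet measured. It carries methylamino in place of fluoro on an aromatic carbon, para to a fluoro group (methylamino in place of fluoro on an aromatic carbon). Within the data shown here, no measured pair shows this change, so the expectation is loose. The expected step of a 1.5-fold lower number from compound 2 to compound 3 (0.19 log units; within the scatter) is modest, toward a lower number in this assay. For compound 3 the estimated value is 30 ug/mL, with an expected range of 9 ug/mL to 100 ug/mL.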

Compound 3, half-maximal inhibitory concentration: 53 ug/mL
The estimate for compound 3 lay 1.8-fold (0.25 log units) below the measured number; the range from low to high includes it.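

In this assay, methylamino in place of fluoro on this aromatic carbon, ortho to a fluoro group and para to a fluoro group, gives a 1.2-fold higher number from compound 2 to compound 3 (0.06 log units; within the scatter), so this pair does not separate. Within the data shown here, this is the first measured pair for the change, and adding a hydrogen-bond donor and a hydrogen-bond acceptor here leaves the read-out within the scatter. Nothing available accounts for this result. Open, going by these compounds, is whether an unsubstituted amino group or ethylamino on this carbon would also stay level with compound 2. Also open, on these data alone, is whether the same holds with another amine in place of the 3-((ethylamino)methyl)pyrrolidin-1-yl group.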